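The source may hold more compounds than are shown below. What is called first, only, known or untested is meant among the compounds shown, and "the series" means these compounds.

Compound 1 `C=C[C@@](C)(/C=C/c1ccc(O)cc1)CC/C=C/C(=O)OCC`: > 49000 nM
Compound 2 `C=C[C@@](C)(/C=C/c1ccc(O)cc1)CC/C=C/C(=O)OCc1ccccc1`: > 49000 nM
Compound 3 `C=C[C@@](C)(/C=C/c1ccc(O)cc1)CC/C=C(C)/C=C/C(=O)OCC`: > 49000 nM

In a functional assay on Jurkat cells (Homo sapiens) for cytotoxicity, with a stated time of 72 h (on this read-out lower numbers stand for an effect already at smaller amounts and higher numbers for an effect only at larger amounts of compound), compound 1 gives > 49000 nM, which is a limit of the assay and not a number. Compound 2 likewise gives a limit, > 49000 nM. Compound 3 gives a limit as well, > 49000 nM. Compound 2 differs from compound 1 by phenyl in place of methyl on a saturated chain carbon bound to an oxygen next to a carbonyl group. The step that the two limits leave unreadable from compound 1 to compound 2 cannot be read because the limit of > 49000 nM in this assay, at which 3 of the 3 values shown sit, holds both values. How the core of compound 3 differs from the core of compound 1 is not broken down here.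

Compound 4 `C=C[C@@](C)(/C=C/c1ccc(O)cc1)CC/C=C(C)/C=C/C(=O)OCc1ccccc1` is not yet measured. Going by the values given here, it differs from compound 3 by phenyl in place of methyl on a saturated chain carbon bound to an oxygen next to a carbonyl group, the same change, at the same place, as the one from compound 1 to compound 2. Since compound 3 sits at a limit, > 49000 nM, and the same change on compound 1 left compound 2 at a limit too, compound 4 is expected to remain at the limit in this assay. Compound 4 is therefore estimated at about 60000 nM, most likely between 20000 nM and 200000 nM. The step this estimate implies, a step that the limit leaves unreadable from compound 3 to compound 4, is expected to be negligible.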

Compound 4, half-maximal effective concentration: > 49000 nM
Compound 4: only a limit was reported; the forecaster's own chance of this, stated with the estimate: 85%; the middle value does not contradict the limit.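

No step can be read from compound 3 to compound 4 in this assay, because both compounds sit at the same limit: the limit of > 49000 nM in this assay, at which 4 of the 4 values shown sit. The compounds shown leave open the size of the change from ethyl to benzyl on either core, and whether any of the four has a half-maximal effective concentration that can be stated as a number.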